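The source may report more compounds than this note shows. Statements on the series, on what has been measured and on what is new or still open speak of the compounds shown alone.

Measured so far in a functional assay on MCF7 cells (Homo sapiens) for antiproliferative activity, read by sulforhodamine B assay, with a stated time of 48 h (on this read-out lower numbers stand for stronger inhibition and higher numbers for weaker inhibition), are these compounds
- Compound 1 `O=C1NCCN1c1ccc(S(=O)(=O)Nc2ccc(I)cc2)cc1` gives 600 nM
- Compound 2 `CCc1ccc(NS(=O)(=O)c2ccc(N3CCNC3=O)cc2)cc1` gives 810 nM
- Compound 3 `O=C1NCCN1c1ccc(S(=O)(=O)Nc2cccc(Oc3ccccc3)c2)cc1` gives 220 nM

Compound 3 has the lowest number of the three, and the values of compound 1 and compound 2 both lie beyond the scatter above it. The next compound to test is compound 4 `COc1cccc(NS(=O)(=O)c2ccc(N3CCNC3=O)cc2)c1` in which one group changes, phenoxy to methoxy. The counted difference is methyl in place of phenyl on an oxygen on an aromatic ring and amounts to methyl in place of phenyl on an oxygen on an aromatic ring.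

Among the compounds with values here, no measured step covers this change. Within the data shown here, the only step available, a 1.4-fold higher number from compound 1 to compound 2 (0.13 log units; within the scatter) as ethyl replaces iodo, involves other groups and stays within the scatter. Among the measured compounds shown here, the best guide is therefore that compound 3 at 220 nM is the only compound with phenoxy and has the lowest number. Losing the phenyl is thus expected to raise the number in this assay towards those of compound 1 and compound 2. The expected change is a 3.6-fold higher number from compound 3 to compound 4 (0.56 log units; beyond the scatter) and is only a rough estimate. The estimated value for compound 4 is 800 nM within an expected range of 280 nM to 2500 nM as the likely span.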

Compound 4, half-maximal inhibitory concentration: 120 nM
The estimate for compound 4 lay 6.7-fold (0.82 log units) above the measured number; measured number below the stated range.
By their numbers in this assay, from the lowest: compounds 4 and 3 (each within the scatter of the next); then compounds 1 and 2 (each within the scatter of the next).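

In this assay, the step from phenoxy to methoxy is a 1.8-fold lower number from compound 3 to compound 4 (0.26 log units; within the scatter), so the outer phenyl is not needed to keep this level of activity, and methyl on that oxygen serves as well. The low number is therefore not tied to phenoxy alone: 3-methoxyphenyl in place of 4-iodophenyl gives a 5.0-fold lower number from compound 1 to compound 4 (0.70 log units; beyond the scatter), and 3-methoxyphenyl in place of 4-ethylphenyl gives a 6.8-fold lower number from compound 2 to compound 4 (0.83 log units; beyond the scatter), both modest steps. No measurement here explains why methyl and phenyl on the oxygen give such similar numbers.

Those last two steps change both the group and where it sits, so they cannot separate one effect from the other. From the compounds shown here alone, it also remains open what a free hydroxyl, a longer chain such as ethoxy, or an amine would give in place of methoxy.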